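The compounds below may be only part of what the source reports. "The series", "measured", "known", "first", "only" and "open" are said of these compounds alone.

Measured so far in a toxicity assay on PC-12 cells (Rattus norvegicus) for cytotoxicity, read by MTT assay; a lower number here means a stronger inhibitor, a higher number a weaker inhibitor:
- compound 1 `CCc1ccc(-n2nc(-c3ccc(C(F)(F)F)cc3O)nc2-c2ccccc2O)cc1`: 147000 nM
- compound 2 `Oc1cc(C(F)(F)F)ccc1-c1nc(-c2ccccc2O)n(-c2ccc(I)cc2)n1`: 73300 nM

Within the data shown here, compound 2 lies within the usual scatter of compound 1, the only other compound with a number, so neither can be called the stronger inhibitor. The next compound, compound 3 `Oc1cc(C(F)(F)F)ccc1-c1nc(-c2ccccc2O)n(-c2cccc(C(F)(F)F)c2)n1`, keeps the shared core and has 3-(trifluoromethyl)phenyl in place of 4-iodophenyl on an aromatic nitrogen.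

Among the measured compounds shown here, only one measured step bears on this: a 2.0-fold lower number from compound 1 to compound 2 (0.30 log units; within the scatter). That step put iodo in place of ethyl on the same aromatic ring and stayed within the scatter. For the measured compounds named here, it is thin evidence, and no measured compound carries trifluoromethyl on this ring. No shift beyond the scatter is therefore expected in this assay. The expected change is a 1.2-fold higher number from compound 2 to compound 3 (0.09 log units; within the scatter). Compound 3 is estimated at 90000 nM, with an expected range from 35000 nM to 230000 nM.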

Compound 3, half-maximal inhibitory concentration: 49700 nM
Beside the measured number, compound 3's estimate is 1.8-fold (0.26 log units) above it, and the stated range covers the measured number.
By their numbers in this assay, from the lowest: compounds 3, 2 and 1 (each within the scatter of the next, the first and the last beyond it).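

In this assay, among these compounds, a change to the group on the aromatic nitrogen now gives a step beyond the scatter for the first time: 3-(trifluoromethyl)phenyl in place of 4-ethylphenyl gives a 3.0-fold lower number from compound 1 to compound 3 (0.47 log units; beyond the scatter), a modest step. Against 4-iodophenyl, the same group gives a 1.5-fold lower number from compound 2 to compound 3 (0.17 log units; within the scatter), so compound 3 cannot be told apart from compound 2 at this position. Nothing available here explains either step.

Compound 3 differs from compound 1 in both the group on the phenyl ring and where that group sits, so the two cannot be separated. Going by these compounds, how this position would respond to a phenyl ring carrying an amine or a carboxylic acid also remains open.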